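The source may hold more compounds than are shown below. What is called first, only, known or untested is meant among the compounds shown, and "the series" means these compounds.

Measured compounds in a functional assay on MCF7 cells (Homo sapiens) for cytotoxicity, read by MTT assay, with a stated time of 48 h; a higher number here means a weaker inhibitor, a lower number a stronger inhibitor:

- compound 1, `CCN(CC)c1ccc2cc(C(=O)c3ccc(N4CCN(S(=O)(=O)c5ccc(C(F)(F)F)cc5)CC4)cc3)oc2c1`; its value is a limit of the assay, > 40000 nM
- compound 2, `CCN(CC)c1ccc2cc(C(=O)c3ccc(N4CCN(S(=O)(=O)c5ccc(F)cc5)CC4)cc3)oc2c1`; 21700 nM
- compound 3, `CCN(CC)c1ccc2cc(C(=O)c3ccc(N4CCN(C(C)=O)CC4)cc3)oc2c1`; 16200 nM

Compound 3 stands lowest of the two numbers in this assay; its nearest neighbour is compound 2, and the step of a 1.3-fold lower number from compound 2 to compound 3 (0.13 log units; within the scatter) lies within the scatter. The step of an at least 1.8-fold lower number from compound 1 to compound 2 (0.26 log units; that floor lies within the scatter) cannot be sized properly, since the value of compound 1 is only a limit (the limit of > 40000 nM in this assay, at which 1 of the 3 values shown sits).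

Compound 4, `CCN(CC)c1ccc2cc(C(=O)c3ccc(N4CCN(S(C)(=O)=O)CC4)cc3)oc2c1`, is not yet measured. It differs from compound 3 as follows: methylsulfonyl in place of acetyl on an amine nitrogen in a ring. Going by the values given here, the one measured step that bears on this place is the step from compound 2 to compound 3, where the group on the ring nitrogen was also exchanged, and that step stayed within the scatter. The step from compound 1 to compound 2 touches a distant aromatic carbon and gives no floor on the present change. No step beyond the scatter is therefore expected in this assay for the move to compound 4.

Compound 4 is expected to give about 16000 nM, within 7000 nM to 38000 nM, in this assay. This estimate means a step of a 1.0-fold lower number from compound 3 to compound 4 (0.01 log units; within the scatter), which is expected to remain within the scatter.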

Compound 4, half-maximal inhibitory concentration: > 40000 nM
Compound 4 gave a limit, no number; the forecaster's own chance of this, stated with the estimate: 15%; middle value at least 2.5-fold (0.39 log units) away from the limit.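

In this assay compound 4 gives > 40000 nM, which is a limit of the assay and not a number, and it shares that position with compound 1: the limit of > 40000 nM in this assay, at which 2 of the 4 values shown sit.

The group on this ring nitrogen now shows a change beyond the scatter, with an at least 2.4-fold higher number from compound 3 to compound 4 (0.39 log units; beyond the scatter), whereas the earlier exchange at the same place, a 1.3-fold lower number from compound 2 to compound 3 (0.13 log units; within the scatter), stayed within it. A sulfonyl on this nitrogen does not go with the loss on its own, since compound 2 also carries one and stays within the scatter of compound 3; methyl in place of 4-fluorophenyl on the sulfonyl sulfur gives an at least 1.8-fold higher number from compound 2 to compound 4 (0.26 log units; that floor lies within the scatter), and the step between the two limits, compound 1 and compound 4, cannot be read.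

Going by these compounds, how far compound 4 lies past the limit remains unknown, so the true size of both steps is open. Also open, on these data alone, is whether the acetyl result extends to other acyl groups such as propanoyl or benzoyl, or to a simple methyl or a free amine on this nitrogen.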